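Halogen swap on the aryl ring of a TRPV1 antagonist series

A few compounds are considered here, and "the series" means these few. Any claim that something is new, unique, unknown or untested is made for them only; others in the source may bear on it.

Of the compounds shown here, two have numbers so far. Compound 1 `COCCCNC(=O)c1noc(-c2ccc(C(F)(F)F)cc2)c1Cl` gives 2210 nM in a functional assay on CHO cells for antagonist activity at transient receptor potential cation channel subfamily V member 1 (Homo sapiens), read by fluorescence and calcium flux; on this read-out lower numbers stand for stronger inhibition and higher numbers for weaker inhibition. Compound 2 `O=C(NC1CCCC1)c1noc(-c2ccc(Br)cc2)c1Br` gives 410 nM in this assay, the lowest of the two numbers; its nearest neighbour is compound 1, whose number is higher by a gap beyond the scatter. The two compounds differ in several places at once, so nothing can be drawn from that gap about any single change.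

Compound 3 `O=C(NC1CCCC1)c1noc(-c2ccc(Cl)cc2)c1Br` is not yet measured. It differs from compound 2 in one place: chloro in place of bromo on an aromatic carbon. Within the data shown here, no measured pair with this single change exists, so the size of the step is not known. The expectation is a step in this assay that stays within or close to the scatter, if anything towards a slightly higher number, as a 1.5-fold higher number from compound 2 to compound 3 (0.17 log units; within the scatter). For compound 3 the estimate in this assay is 600 nM, within 250 nM to 1500 nM.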

Compound 3, half-maximal inhibitory concentration: 370 nM
Estimate against measurement, compound 3: 1.6-fold (0.21 log units) above; the range from low to high includes it.
By their numbers in this assay, from the lowest: compounds 3 and 2 (each within the scatter of the next); then compound 1.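

In this assay the series now has its first pair differing in one place, and it gives a 1.1-fold lower number from compound 2 to compound 3 (0.04 log units; within the scatter) with the rest of the structure unchanged. On this read-out, 4-bromophenyl and 4-chlorophenyl therefore cannot be told apart at this aromatic carbon, para to a large group, at least with this amide and this core. Nothing available bears on why the two halogens read alike here.

Going by these compounds, whether the same holds for other groups at this place, such as fluoro, methoxy or nitrile, remains open. Also open, on these data alone, is whether chloro and bromo stay interchangeable on the aryl ring when the amide carries a different substituent, such as the longer methoxypropyl chain of compound 1.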